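Swapping the sulfonyl aryl group at a glutamate receptor

The compounds below may be only part of what the source reports. "The series", "measured", "known", "first", "only" and "open" are said of these compounds alone.

Measured compounds:
- Compound 1, `CC1CCN(c2c(S(=O)(=O)c3ccc(F)c(Cl)c3)cnc3cc(F)ccc23)CC1`: 94%
- Compound 2, `CC1CCN(c2c(S(=O)(=O)c3ccc(F)c(Cl)c3)cnc3cc(Cl)ccc23)CC1`: 94%
- Compound 3, `NS(=O)(=O)N1CCN(c2c(S(=O)(=O)c3cc(F)cc(F)c3)cnc3cc(F)ccc23)CC1`: 6.4%

In an assay on isolated protein for displacement of a labelled ligand from metabotropic glutamate receptor 5 (Homo sapiens), with a stated time of 60 min, tested at 1 uM (a higher number here means more inhibition at the concentration tested (going by the name of the read-out), a lower number less inhibition), compound 1 gives 94%, level with compound 2 at the digits shown and far above compound 3, whose value of 6.4% is lower than that of compound 1 by an amount well beyond the scatter. Compound 3 differs from compound 1 in more than one place, so its low number cannot be tied to any single change.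

The step to compound 4, `CC1CCN(c2c(S(=O)(=O)c3cccc(C#N)c3)cnc3cc(F)ccc23)CC1`, is 3-cyanophenyl in place of 3-chloro-4-fluorophenyl on a sulfonyl sulfur. Among the measured compounds shown here, the only single-point step measured, no change at the digits printed from compound 1 to compound 2 (within the scatter), concerns a different position and shows no change, so it says nothing direct about altering the aryl group on the sulfonyl sulfur. For the measured compounds named here, no measured pair isolates that change. With only an unrelated flat step and one multi-point drop to lean on, the expectation is that the number for compound 4 stays high but may fall somewhat, an estimated step of a number 19 percentage points lower from compound 1 to compound 4 (beyond the scatter). Compound 4 is therefore expected to give about 75%, within a range from 40% to 95%.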

Compound 4, a percentage reported as inhibition, at one concentration (the size of the read-out at that concentration, not a potency): 92%
Compound 4: middle estimate off by 17 percentage points, on the low side, within the range that was stated.
By their numbers in this assay, from the lowest: compound 3; then compounds 4, 1 and 2 (each within the scatter of the next).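

In this assay, 3-cyanophenyl in place of 3-chloro-4-fluorophenyl on the sulfonyl sulfur gives a number 2 percentage points lower from compound 1 to compound 4 (within the scatter). Among the compounds shown here, this is the first single-place change to this aryl group, and it shows that the ring's two halogens can give way to one nitrile with no change beyond the scatter, so this change leaves the inhibition at the tested concentration high. No measurement shown here explains why the two aryl groups read alike.

On these data alone, because each number comes from a single concentration, it is open whether compound 1 and compound 4 would still match in potency across a range of concentrations. As far as these compounds go, it is also open whether this position would keep its high reading with a ring bearing an amine or a carboxylic acid, or with a saturated cyclohexyl ring in place of the aryl group.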